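A few compounds are considered here, and "the series" means these few. Any claim that something is new, unique, unknown or untested is made for them only; others in the source may bear on it.

Measured in a functional assay on MDA-MB-231 cells (Homo sapiens) for inhibition, read by MTT assay, with a stated time of 72 h; on this read-out lower numbers stand for stronger inhibition and higher numbers for weaker inhibition:
- Compound 1 `Nc1nc2cc(-c3nn(CCCCCCCCCC(=O)NO)c4ncnc(N)c34)ccc2o1`: > 50000 nM, a limit of the assay
- Compound 2 `Nc1nc2cc(-c3nn(CCCCC(=O)NO)c4ncnc(N)c34)ccc2o1`: 21200 nM
- Compound 3 `Nc1nc2cc(-c3nn(CCCCCCCCC(=O)NO)c4ncnc(N)c34)ccc2o1`: 30300 nM

Compound 3 lies within the scatter of compound 2, and the only other result, for compound 1, is a limit. Compound 4 `CNC(=O)CCCCCCCn1nc(-c2ccc3oc(N)nc3c2)c2c(N)ncnc21` carries methylcarbamoyl in place of the (hydroxycarbamoyl)methyl of compound 3, on a saturated chain carbon: methylcarbamoyl in place of (hydroxycarbamoyl)methyl on a saturated chain carbon, seven bonds along the chain from an aromatic nitrogen. The measured steps concern chain length only: an at least 2.3-fold lower number from compound 1 to compound 2 (0.37 log units; beyond the scatter) lies beyond the scatter, the floor of an at least 1.6-fold lower number from compound 1 to compound 3 (0.21 log units; that floor lies within the scatter) lies within it, and a 1.4-fold higher number from compound 2 to compound 3 (0.16 log units; within the scatter) lies within it. Among the measured compounds shown here, all three compounds carry hydroxycarbamoyl, so no measured step shows its replacement, and these steps are only a weak guide. No change beyond the scatter is therefore expected in this assay, and the expected step is a 1.2-fold higher number from compound 3 to compound 4 (0.06 log units; within the scatter). Compound 4 is estimated at 35000 nM, within an expected range of 12000 nM to 100000 nM.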

Compound 4, half-maximal inhibitory concentration: 2900 nM
Compound 4: middle estimate off by 12-fold (1.08 log units), on the high side; the measured number lies below the stated range.
By their numbers in this assay, from the lowest: compound 4; then compounds 2 and 3 (each within the scatter of the next). At a limit, above all of these: compound 1.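

In this assay, among the compounds shown here, the first measured change at the chain end gives a 10-fold lower number from compound 3 to compound 4 (1.02 log units; beyond the scatter), and against a shorter hydroxycarbamoyl chain it gives a 7.3-fold lower number from compound 2 to compound 4 (0.86 log units; beyond the scatter). So methylcarbamoyl at this position moves the number beyond the scatter, which the step between compound 2 and compound 3 did not do. Compound 1 stands at a limit, so an at least 17-fold lower number from compound 1 to compound 4 (1.23 log units; beyond the scatter) is only a floor: the limit of > 50000 nM in this assay, at which 1 of the 4 values shown sits.

Open, from the compounds shown here alone, is how a carboxylic acid, a primary amide or an ethyl amide at the chain end would read. Also open, going by these compounds, is whether methylcarbamoyl keeps this number on a shorter or a longer chain.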